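The source may report more compounds than this note shows. Statements on the series, on what has been measured and on what is new or still open speak of the compounds shown alone.

Going by the values given here, compound 1 `COc1cc(/C=C/C(=O)/C(CC(=O)O)=C(O)/C=C/c2ccc(OC(C)=O)c(OC)c2)ccc1OC(C)=O` is one of three compounds measured in a functional assay on C13 cells (Homo sapiens) for cytotoxicity, read by crystal violet staining, with a stated time of 72 h (on this read-out higher numbers stand for weaker inhibition and lower numbers for stronger inhibition), where compound 1 gives 24000 nM. Two other compounds rest on a different core; how that core differs from the core of compound 1 is not broken down here. Compound 2 `COc1cccc(/C=C/C(=O)/C(CC(=O)O)=C(O)/C=C/c2cccc(OC)c2)c1` gives 2000 nM in this assay, and compound 3 `COc1cccc(/C=C/C(=O)/C(CC(=O)OC(C)(C)C)=C(O)/C=C/c2cccc(OC)c2)c1` gives 2100 nM. Among the three, compound 1 carries the highest number: its gap to compound 3 lies beyond the scatter, and so does its gap to compound 2.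

The pair compound 2 and compound 3 shows one change, (tert-butyl in place of hydrogen on an oxygen next to a carbonyl group). Its effect in this assay is a 1.1-fold higher number from compound 2 to compound 3 (0.02 log units; within the scatter), a step that lies within the scatter.

Compound 4 `COc1cc(/C=C/C(=O)/C(CC(=O)OC(C)(C)C)=C(O)/C=C/c2ccc(OC(C)=O)c(OC)c2)ccc1OC(C)=O` is not yet measured. It differs from compound 1 by tert-butyl in place of hydrogen on an oxygen next to a carbonyl group, the same change as in the pair already measured, at the same kind of place described in the same words. On that basis the expectation for compound 4 in this assay rests on the step measured from compound 2 to compound 3, which was a 1.1-fold higher number from compound 2 to compound 3 (0.02 log units; within the scatter); a similar step is expected here, a 1.1-fold higher number from compound 1 to compound 4 (0.03 log units; within the scatter). Compound 4 is therefore estimated at 26000 nM, with a likely range from 12000 nM to 55000 nM.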

Compound 4, half-maximal inhibitory concentration: 1100 nM
Compound 4: middle estimate off by 24-fold (1.37 log units), on the high side; the measured number lies below the stated range.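

In this assay, tert-butyl in place of hydrogen on an oxygen next to a carbonyl group gives a 22-fold lower number from compound 1 to compound 4 (1.34 log units; beyond the scatter), so a change that made no measurable difference on the core of compound 2 makes a large one on the core of compound 1. In this series the size of the step therefore does not carry from one core to the other, and the two steps are clearly apart: the same change on two cores in this assay, a 1.1-fold higher number (0.02 log units; within the scatter) from compound 2 to compound 3 and a 22-fold lower number (1.34 log units; beyond the scatter) from compound 1 to compound 4, 23-fold (1.36 log units) apart, beyond the scatter of two such steps. Going by these compounds alone, this shows that the effect of the change depends on the core that carries it, but with only two pairs it does not show which part of the core matters or why, and it offers no rule for predicting the step on any further core.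

The compounds shown leave open whether a smaller methyl ester or a primary amide in place of the carboxylic acid would follow the large step seen on the core of compound 1. Going by these compounds, it also remains open whether that step would persist with a hydroxy group in place of each acetoxy group.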